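Amide to urea exchange on a shared core: cytotoxicity expectation

This account rests on a few compounds, and the source may have more. Where it says the series, first, only, none or still open, it means among the compounds named here.

Measured compounds:
compound 1, `COc1cc(-c2nn(-c3cccc(NC(=O)c4ccc(Cl)c(C(F)(F)F)c4)c3)cc2-c2ccncc2)ccc1Cl`, 24700 nM
compound 2, `O=C(Nc1cccc(-n2cc(-c3ccncc3)c(-c3ccc(Cl)c(O)c3)n2)c1)Nc1ccc(Cl)c(C(F)(F)F)c1`, 21500 nM

In a functional assay on MDA-MB-435 cells (Homo sapiens) for inhibition, read by sulforhodamine B assay, with a stated time of 48 h (on this read-out higher numbers stand for lower toxicity in this test and lower numbers for higher toxicity in this test), compound 1 gives 24700 nM, the highest of the two numbers shown, while compound 2 gives 21500 nM, a value within the scatter of that of compound 1. Compound 3, `COc1cc(-c2nn(-c3cccc(NC(=O)Nc4ccc(Cl)c(Cl)c4)c3)cc2-c2ccncc2)ccc1Cl`, has not been measured. It differs from compound 1 by (3,4-dichlorophenyl)amino in place of 4-chloro-3-(trifluoromethyl)phenyl on a carbonyl carbon. Among the compounds with values here, no step between measured compounds covers this change; compound 2, which also carries an amide-type nitrogen on its carbonyl, shows no separation from compound 1, so no step beyond the scatter is expected. The estimated step of a 1.1-fold lower number from compound 1 to compound 3 (0.05 log units; within the scatter) for compound 3 is small. Compound 3 is expected at 22000 nM, between 8000 nM and 60000 nM.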

Compound 3, concentration lethal to 50% of the cells: > 50000 nM
Compound 3 gave a limit, no number; the forecaster's own chance of this, stated with the estimate: 10%; middle value at least 2.2-fold (0.35 log units) away from the limit.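

Compound 3 reads in this assay only as a limit, not as a number: the limit of > 50000 nM in this assay, at which 1 of the 3 values shown sits. Within the data shown here, the exchange on this carbonyl carbon gives an at least 2.0-fold higher number from compound 1 to compound 3 (0.30 log units; that floor lies within the scatter), the first one-place step at this position. It shows no sign of higher toxicity in this test, although its floor alone does not establish a separation.

On these data alone, how far the true value of compound 3 lies past the limit remains open, as does whether the added amino nitrogen or the chlorine in place of trifluoromethyl drives the step. A plain phenylamino or a 4-methoxyphenylamino group on the same carbon could help separate these.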